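This account rests on a few compounds, and the source may have more. Where it says the series, first, only, none or still open, it means among the compounds named here.

Series notes. In a functional assay on BGC-823 cells (Homo sapiens) for antiproliferative activity, read by MTT assay, tested at 5 uM (a lower number here means a weaker effect, a higher number a stronger effect of the compound at the concentration tested), compound 1 `COc1ccc(OC)c(/C=N/NC(=O)c2cc(OC)c(OC)c(OC)c2)c1` gives 10.1%, compound 3 `COc1cc(C(=O)N/N=C/c2ccc(Cl)c([N+](=O)[O-])c2)cc(OC)c1OC` gives 2.3%, and compound 2 `COc1ccc(C2OC(c3cc(OC)c(OC)c(OC)c3)=NN2C(C)=O)c(OC)c1` gives -3.1%. Compound 2 stands lowest of the three numbers in this assay; its gap to compound 3 lies within the scatter, whereas its gap to compound 1 lies beyond the scatter. Among the compounds with values here, compound 4 `COc1cc(C2=NN(C(C)=O)C(c3c(Cl)cccc3Cl)O2)cc(OC)c1OC` differs from compound 2 at one place: 2,6-dichlorophenyl in place of 2,4-dimethoxyphenyl on a saturated ring carbon No pair of measured compounds covers this change, so the measured set gives no ground for a step beyond the scatter in this assay in either direction. The expected step in this assay is a number 7.1 percentage points higher from compound 2 to compound 4 (within the scatter), which stays within the scatter. For compound 4 in this assay the estimated value is 4%, with a range of -10% to 20%.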

Compound 4, a percentage reported as inhibition, at one concentration (the size of the read-out at that concentration, not a potency): 15.9%
Compound 4: the middle estimate sits 11.9 percentage points below what was measured; the range from low to high includes it.
By their numbers in this assay, from the lowest: compounds 2, 3, 1 and 4 (each within the scatter of the next, the first and the last beyond it).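

In this assay, the aryl group on the saturated ring carbon proves able to move the read-out, with a number 19 percentage points higher from compound 2 to compound 4 (beyond the scatter). Within the data shown here, this is the first measured single-place change, and it shows that 2,6-dichlorophenyl in place of 2,4-dimethoxyphenyl is a step upward at this concentration, though not a measure of potency. Nothing available explains the step.

Still open, as far as these compounds go, is whether the entering chlorines or the leaving methoxy groups carry the step, as both change together. From the compounds shown here alone, how an aryl group bearing an amine or a carboxylic acid would read at this carbon also remains open.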